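Lengthening the Side Chain of Compound 2

The source may report more compounds than this note shows. Statements on the series, on what has been measured and on what is new or still open speak of the compounds shown alone.

Compound 2 `COc1ccc(N(C)c2nc(C)nc3ccccc23)cc1OCC[Se]C#N` stands lowest of the two numbers seen so far; in a functional assay on HepG2 cells (Homo sapiens) for inhibition, read by MTT assay, with a stated time of 48 h (on this read-out lower numbers stand for stronger inhibition and higher numbers for weaker inhibition), compound 2 gives 14 nM. Going by the values given here, its nearest neighbour, compound 1 `COc1ccc(N(C)c2nc(C)nc3ccccc23)cc1C(=O)OCCC[Se]C#N`, gives 340 nM in this assay, and the move a 24-fold lower number from compound 1 to compound 2 (1.39 log units; beyond the scatter) is the only measured step. Compound 3 `COc1ccc(N(C)c2nc(C)nc3ccccc23)cc1OCCCCC[Se]C#N` is not yet measured. It differs from compound 2 as follows: a group of 6 heavy atoms (4 carbon, 1 nitrogen, 1 selenium; no ring) in place of a group of 3 heavy atoms (1 carbon, 1 nitrogen, 1 selenium; no ring), on a saturated chain carbon, two bonds along the chain from an oxygen on an aromatic ring. Among the compounds with values here, the single measured step exchanged one group for another on an aromatic carbon, and so does not bear directly on a lengthening of the saturated chain; no step of that kind is available. Within the data shown here, with one large step of a different kind as the only guide, the expected step from compound 2 to compound 3 is small, a 2.1-fold higher number from compound 2 to compound 3 (0.33 log units; beyond the scatter), with the direction uncertain and possibly none beyond the scatter. Compound 3 is therefore estimated at 30 nM, with a range from 8 nM to 120 nM.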

Compound 3, half-maximal inhibitory concentration: 5210 nM
Beside the measured number, compound 3's estimate is 170-fold (2.24 log units) below it; measured number above the stated range.
By their numbers in this assay, from the lowest: compound 2; then compound 1; then compound 3.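

In this assay, going by these compounds alone, the side chain proves highly sensitive to lengthening: the group of 6 heavy atoms in place of the group of 3 heavy atoms, on a saturated chain carbon, two bonds along the chain from an oxygen on an aromatic ring, gives a 370-fold higher number from compound 2 to compound 3 (2.57 log units; beyond the scatter), the largest step so far. Heavy-atom count alone does not set the number, as two groups of 9 heavy atoms on an aromatic carbon give a 15-fold higher number from compound 1 to compound 3 (1.19 log units; beyond the scatter). No evidence is available that bears on the origin of these steps.

The compounds shown do not tell whether the loss sets in gradually or abruptly at a chain length in between, or whether a longer chain would continue it. Also open, from the compounds shown here alone, is how the chain would behave with an amine or a carboxylic acid in place of the selenium and nitrile end.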